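The source may report more compounds than this note shows. Statements on the series, on what has been measured and on what is new or still open speak of the compounds shown alone.

Measured so far:

Compound 1 `Nc1scc(CN2CCN(c3ccc(Cl)cc3Cl)CC2)c1C(=O)c1ccc(Cl)cc1` gives 0% in an assay on CHO cells for displacement of a labelled ligand from adenosine receptor A1 (Homo sapiens), read by scintillation counting, with a stated time of 120 min, tested at 10 uM; a lower number here means less inhibition, a higher number more inhibition at the concentration tested (going by the name of the read-out).
Compound 2 `Nc1scc(CN2CCN(c3cc(Cl)cc(Cl)c3)CC2)c1C(=O)c1ccc(Cl)cc1` gives 1% in this assay.

On the numbers shown, compound 2 and compound 1 sit together at the bottom of the scale, with a gap between them that is within the scatter, so neither can be set apart from the other; both show essentially no displacement of the labelled ligand. Compound 3 `Nc1scc(CN2CCN(c3ccc(F)cc3Cl)CC2)c1C(=O)c1ccc(Cl)cc1` is the next compound, not yet measured. It differs from compound 2 in one place: 2-chloro-4-fluorophenyl in place of 3,5-dichlorophenyl on an amine nitrogen in a ring. Among the compounds with values here, the one measured step that touches the same place is the exchange of one dichlorophenyl pattern for another on the ring nitrogen, a number 1 percentage points higher from compound 1 to compound 2 (within the scatter), which changed nothing beyond the scatter. Since the shared core with two different substitution patterns on that aryl group gave no measurable inhibition either time, a third pattern with one chlorine and one fluorine is expected to behave the same way, and the step is estimated at a number 1 percentage points higher from compound 2 to compound 3 (within the scatter), that is, none beyond the scatter. Compound 3 is therefore expected to give about 2% in this assay, with a range from 0% to 12%.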

Compound 3, a percentage reported as inhibition, at one concentration (the size of the read-out at that concentration, not a potency): 0%
Compound 3: middle estimate off by 2 percentage points, on the high side; the measured number falls inside the stated range.
By their numbers in this assay, from the lowest: compounds 1, 3 and 2 (each within the scatter of the next).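

The exchange of a single halogen, fluoro in place of chloro on an aromatic carbon of the aryl group on the ring nitrogen, is new here, and in this assay it gives no change at the digits printed from compound 1 to compound 3 (within the scatter). The wider change, 2-chloro-4-fluorophenyl in place of 3,5-dichlorophenyl, gives a number 1 percentage points lower from compound 2 to compound 3 (within the scatter), so compound 1, compound 2 and compound 3 now show three halogen patterns at this position on the shared core, and none of them separates from the others or rises off the bottom of the scale at the concentration tested. No measurement available here offers an explanation for this lack of displacement of the labelled ligand.

As far as these compounds go, what stays open is whether anything other than chlorine or fluorine on this aryl ring, such as a methoxy group, a hydroxyl or an amine, or a pyridine ring or a benzyl group in place of the aryl group itself, would lift the number off the bottom of the scale. With all three compounds this low, the read-out also cannot say whether this position matters at all for the receptor, or whether a change elsewhere on the shared core would have to come first.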